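Working notes: amino in place of hydrogen on compound 1

A few compounds are considered here, and "the series" means these few. Any claim that something is new, unique, unknown or untested is made for them only; others in the source may bear on it.

compound 1 `CCCCCCCCCCCCOc1ncnc2c1ncn2CC(=O)OCC` reads > 10 ug/mL (a limit)
compound 2 `CCCCCCCCCCCCOc1ncnc2[nH]cnc12` reads "not determined" (no result reported)
compound 3 `CCCCCCCCCCSc1ncnc2c1ncn2CC` reads "not determined" (no result reported)
compound 4 `CCCCCCCCCCCCOc1nc(N)nc2c1ncn2CC(=O)OCC` is not yet measured

In an ADME assay on Vero cells (Chlorocebus sabaeus) for cytotoxicity (on this read-out higher numbers stand for lower toxicity in this test and lower numbers for higher toxicity in this test), compound 1 gives > 10 ug/mL as a limit of the assay and not a number. Compound 2 and compound 3 have no result, so compound 1 has no measured neighbour to stand against. Compound 4 differs from compound 1 in one place: amino in place of hydrogen on an aromatic carbon (amino in place of hydrogen on an aromatic carbon, between two ring nitrogen atoms). Within the data shown here, no measured pair shows this change. The expected size of a step that the limit leaves unreadable from compound 1 to compound 4 stays within the usual scatter, with no direction favoured. Compound 4 is estimated at 15 ug/mL with an expected range of 6 ug/mL to 50 ug/mL and may again return only a limit.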

Compound 4, half-maximal cytotoxic concentration: > 10 ug/mL
Compound 4: only a limit was reported; the forecaster's own chance of this, stated with the estimate: 60%; the middle value lies beyond the limit too.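

Compound 1 and compound 4 each return only a limit in this assay, so no step can be read between them: the limit of > 10 ug/mL in this assay, at which 2 of the 4 values shown sit.

From the compounds shown here alone, the size and direction of any effect of amino in place of hydrogen on an aromatic carbon in this assay stay open.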